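A few compounds are considered here, and "the series" means these few. Any claim that something is new, unique, unknown or untested is made for them only; others in the source may bear on it.

Compound 1 `O=C(CC(CC(=O)NC1Cc2ccccc2C1)c1ccccc1)NCCN1CCCC1` gives in a functional assay on A549 cells (Homo sapiens) for inhibition (on this read-out lower numbers stand for stronger inhibition and higher numbers for weaker inhibition), a limit of the assay, > 100000 nM.
Compound 2 `CCN(CC)CCNC(=O)CC(CC(=O)NC1Cc2ccccc2C1)c1ccccc1` gives in this assay 82400 nM.
Compound 3 `CCN(C(=O)CC(CC(=O)NCCN1CCCC1)c1ccc(Cl)cc1)C1Cc2ccccc2C1` gives in this assay 22600 nM.

Compound 1 and compound 2 differ in one place: diethylamino in place of pyrrolidin-1-yl on a saturated chain carbon, two bonds along the chain from an amide-type nitrogen. That change gave an at least 1.2-fold lower number from compound 1 to compound 2 (0.08 log units; that floor lies within the scatter), and its floor rests on a limit, because of the limit of > 100000 nM in this assay, at which 1 of the 3 values shown sits. Compound 3 has the lowest number of the two that are numbers; how its core differs from the core of compound 1 is not broken down here. Compound 4 `CCN(CC)CCNC(=O)CC(CC(=O)N(CC)C1Cc2ccccc2C1)c1ccc(Cl)cc1` carries the same change on the core of compound 3: diethylamino in place of pyrrolidin-1-yl on a saturated chain carbon, two bonds along the chain from an amide-type nitrogen. Because an at least 1.2-fold lower number from compound 1 to compound 2 (0.08 log units; that floor lies within the scatter) was small, the step from compound 3 to compound 4 is expected to be small as well, about a 1.1-fold lower number from compound 3 to compound 4 (0.05 log units; within the scatter). Compound 4 is thus estimated at 20000 nM, between 7000 nM and 60000 nM.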

Compound 4, half-maximal inhibitory concentration: 18400 nM
Compound 4: middle estimate off by 1.1-fold (0.04 log units), on the high side, and the stated range covers the measured number.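

In this assay, putting diethylamino in place of pyrrolidin-1-yl on the core of compound 3 gave a 1.2-fold lower number from compound 3 to compound 4 (0.09 log units; within the scatter). Set beside the earlier step, the change shows no clear effect on either core, and nothing here shows that the two cores respond differently: the same change on two cores in this assay, an at least 1.2-fold lower number (0.08 log units; that floor lies within the scatter) from compound 1 to compound 2 and a 1.2-fold lower number (0.09 log units; within the scatter) from compound 3 to compound 4; the limit leaves it open whether they differ Compound 1 gives a limit of the assay, > 100000 nM, not a number, so the true size of the step on that core remains unknown.

The compounds shown leave open whether another amine on this chain, such as piperidin-1-yl or morpholin-4-yl, or a longer chain carrying the amine, would shift the number beyond the scatter. They also leave open how this change behaves on any further core.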